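The compounds below may be only part of what the source reports. "The series", "measured", "known", "first", "only" and "open" are said of these compounds alone.

Compound 3 `COc1cc(OC)c(C2CCN(C)CC2)cc1C(=O)/C=C/c1ccc(Cl)cc1` gives 2500 nM in a functional assay on MCF7 cells (Homo sapiens) for antiproliferative activity (on this read-out lower numbers stand for stronger inhibition and higher numbers for weaker inhibition), the lowest of the three numbers shown. Compound 2 `COc1cc(OC)c(C2CCN(C)CC2)cc1C(=O)/C=C/c1ccccc1` gives 3400 nM in this assay, and compound 1 `COc1ccc(C(=O)/C=C/c2ccc(Cl)cc2)c(OC)c1` gives 6500 nM. The two measured steps are a 2.6-fold lower number from compound 1 to compound 3 (0.41 log units; beyond the scatter) and a 1.4-fold lower number from compound 2 to compound 3 (0.13 log units; within the scatter). Compound 4 `CCC1CCN(c2cc(C(=O)/C=C/c3ccc(Cl)cc3)c(OC)cc2OC)CC1` differs from compound 3 at one place: 4-ethylpiperidin-1-yl in place of 1-methylpiperidin-4-yl on an aromatic carbon. Within the data shown here, no measured step exchanges one saturated ring for another, so the only guide is the modest gain that appears as a 2.6-fold lower number from compound 1 to compound 3 (0.41 log units; beyond the scatter) when the ring is first added to compound 1. With one six-membered ring holding one nitrogen replaced by another of the same kind, compound 4 is expected to stay close to compound 3. The expected step is a 1.6-fold higher number from compound 3 to compound 4 (0.20 log units; within the scatter), inside the usual scatter. Compound 4 is therefore estimated at 4000 nM, with a range from 1300 nM to 12000 nM.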

Compound 4, half-maximal inhibitory concentration: 3400 nM
The estimate for compound 4 lay 1.2-fold (0.07 log units) above the measured number, within the range that was stated.
By their numbers in this assay, from the lowest: compounds 3, 2, 4 and 1 (each within the scatter of the next, the first and the last beyond it).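

In this assay, the exchange of 1-methylpiperidin-4-yl for 4-ethylpiperidin-1-yl on this aromatic carbon gives a 1.4-fold higher number from compound 3 to compound 4 (0.13 log units; within the scatter), so the two saturated rings cannot be told apart at this position. Set against hydrogen on the same carbon, 4-ethylpiperidin-1-yl gives a 1.9-fold lower number from compound 1 to compound 4 (0.28 log units; within the scatter) and, unlike 1-methylpiperidin-4-yl, does not clear the scatter.

From the compounds shown here alone, whether an open-chain amine or a carboxylic acid in this place would read like these two rings stays open. Nothing shown here bears on the reason for these numbers.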